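Hydrogen for fluoro: compound 3 to compound 4

A few compounds are considered here, and "the series" means these few. Any claim that something is new, unique, unknown or untested is made for them only; others in the source may bear on it.

Measured so far in a toxicity assay on HepG2 cells (Homo sapiens) for cytotoxicity, read by CellTiter-Glo, with a stated time of 72 h; on this read-out lower numbers stand for higher toxicity in this test and higher numbers for lower toxicity in this test
compound 1 `COc1ccc(C(F)(F)F)cc1CN(C)C(c1ccccc1)c1nnnn1-c1ccccc1C` gives "nd" (no result reported)
compound 2 `COc1ccc(C(F)(F)F)cc1CN(C1CC1)C(c1cccnc1)c1nnnn1-c1ccccc1C` gives 16000 nM
compound 3 `Cc1ccccc1-n1nnnc1C(c1cccnc1)N(Cc1cc(C(F)(F)F)ccc1F)C1CC1` gives "nd" (no result reported)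

Compound 3 has no number that places it in the series, and compound 1 has none either. Within the data shown here, the only number comes from compound 2 at 16000 nM and no measured pair tests the change at hand. The next step is hydrogen in place of fluoro on an aromatic carbon and puts hydrogen in place of fluoro on an aromatic carbon, giving compound 4 `Cc1ccccc1-n1nnnc1C(c1cccnc1)N(Cc1cccc(C(F)(F)F)c1)C1CC1` as the product. In this assay a step no larger than the usual scatter is expected, in neither direction. For compound 4 the estimate is 16000 nM with 6000 nM to 45000 nM as the expected range.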

Compound 4, half-maximal cytotoxic concentration: 15000 nM
Estimate against measurement, compound 4: 1.1-fold (0.03 log units) above; measured number inside the range.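

Hydrogen in place of methoxy gives a 1.1-fold lower number from compound 2 to compound 4 (0.03 log units; within the scatter) and is the first step of the series that can be read in this assay, on the ring carrying trifluoromethyl. Steps involving compound 1 or compound 3 cannot be read, so the change from fluoro to hydrogen itself has no size. No available data explain this result.

From the compounds shown here alone, how an amine, a nitrile or a carboxylic acid on this ring would read in this assay stays open. So does whether any change on this ring moves the read-out beyond the scatter.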